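Chalcone ethers on a shared core: cytotoxicity notes

The source may hold more compounds than are shown below. What is called first, only, known or untested is meant among the compounds shown, and "the series" means these compounds.

Measured compounds:
- compound 2, `CNC(=O)c1cc(Oc2ccc(C(=O)/C=C/c3ccc(C#N)cc3)cc2)ccn1`: 3870 nM
- compound 1, `CNC(=O)c1cc(Oc2ccc(/C=C/C(=O)c3ccc(C)cc3)cc2)ccn1`: "not determined" (no result reported)

Within the data shown here, compound 2 carries the only number available. In a functional assay on PC-3 cells (Homo sapiens) for cytotoxicity, read by MTT assay, with a stated time of 72 h (on this read-out lower numbers stand for stronger inhibition and higher numbers for weaker inhibition), compound 2 gives 3870 nM. Compound 1 shares the core but was not read out, so no value can be placed beside it and no comparison with compound 2 is possible.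

The next compound is compound 3, `CNC(=O)c1cc(Oc2ccc(C(=O)/C=C/c3ccccc3)cc2)ccn1`. It differs from compound 2 in one place: hydrogen in place of cyano on an aromatic carbon. Among the measured compounds shown here, no step between two measured compounds exists here, so the size of this change cannot be read from the series itself; it has to be judged from the change alone.

A change of this kind on the outer ring is expected to be small, most likely within the scatter of this assay, with a slight lean toward weaker inhibition if any. The expected step from compound 2 to compound 3 is a 1.4-fold higher number from compound 2 to compound 3 (0.15 log units; within the scatter). Compound 3 is therefore estimated at 5500 nM in this assay, with a range from 2000 nM to 15000 nM.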

Compound 3, half-maximal inhibitory concentration: 3170 nM
For compound 3 the middle estimate is 1.7-fold (0.24 log units) above the measured one; the range from low to high includes it.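

Among these compounds, the step from 4-cyanophenyl to phenyl is the first one that can be read: in this assay it amounts to a 1.2-fold lower number from compound 2 to compound 3 (0.09 log units; within the scatter) and gives the only comparison available so far. On this aromatic carbon, para to a large group, cyano and hydrogen therefore cannot be told apart on this read-out, even though 2 heavy atoms and 1 hydrogen-bond acceptor leave with the cyano group. This finding rests on one pair and sets no trend for other groups at this place. No supporting measurement bears on why the two compounds read alike.

Still open, going by these compounds, is whether a different group at the same place, such as an amine, a carboxylic acid or a longer chain, would produce a step beyond the scatter. On these data alone, compound 1, with its methyl-bearing outer ring and its differently oriented carbonyl and double bond, has no result to compare, so the effect of that arrangement on this read-out remains unknown.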